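The source may report more compounds than this note shows. Statements on the series, on what has been measured and on what is new or still open speak of the compounds shown alone.

Compound 1 `CCC1(Cc2ccccc2)OS(=O)(=O)C=C1OCC#N`: > 400000 nM in an ADME assay on HEL cells (Homo sapiens) for cytotoxicity, with a stated time of 3 days; on this read-out higher numbers stand for lower toxicity in this test and lower numbers for higher toxicity in this test
Compound 2 `CCC1(Cc2ccccc2)OS(=O)(=O)C=C1OCc1ccc(OC)cc1`: >= 200000 nM in this assay

In this assay compound 1 reaches only a limit of the assay, > 400000 nM, and not a number. Compound 2 likewise stops at a limit, >= 200000 nM. The step that the two limits leave unreadable from compound 1 to compound 2 therefore cannot be sized, because both ends are limits the limit of > 400000 nM in this assay, at which 1 of the 2 values shown sits (the limit of >= 200000 nM in this assay, at which 1 of the 2 values shown sits).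

Compound 3 `CCC1(Cc2ccccc2)OS(=O)(=O)C=C1NCc1ccccc1` has not been measured in this assay. Its difference from compound 1 is this: benzylamino in place of cyanomethoxy on a double-bonded ring carbon. Within the data shown here, the only measured step, from compound 1 to compound 2, touches the same side of the core but gives no readable size, so no direction and no size beyond the scatter can be drawn from it. What the two measured compounds show is that both sit at a limit in this assay.

Compound 3 is thus expected near 300000 nM, in a range from 80000 nM to 1000000 nM. The expected step is an at least 1.3-fold lower number from compound 1 to compound 3 (0.12 log units; that floor lies within the scatter), most likely again ending at a limit.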

Compound 3, minimum cytotoxic concentration: >= 80000 nM
Compound 3 was reported as a limit; the forecaster's own chance of this, stated with the estimate: 70%; the middle value does not contradict the limit.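

In this assay compound 3 gives only a limit, >= 80000 nM, and not a number. Among these compounds, compound 1 also stands at a limit, so no step between compound 1 and compound 3 can be read. On these data alone, the actual minimum cytotoxic concentrations of compound 1, compound 2 and compound 3 remain open.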